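The source may hold more compounds than are shown below. What is called first, only, known or untested is meant among the compounds shown, and "the series" means these compounds.

Compound 1 `COC(=O)c1cccc(CN(CCCC(=O)O)C[C@H]2O[C@@H](n3cnc4c(N)ncnc43)[C@H](O)[C@@H]2O)c1` is examined in an assay on cells for inhibition of Nicotinamide N-methyltransferase (Homo sapiens), with stated times of 10 min and 30 min; a lower number here means a stronger inhibitor, a higher number a weaker inhibitor. In this assay compound 1 gives only a limit, > 250000 nM. Compound 2 `COC(=O)c1cccc(CN(CCCCC(=O)O)C[C@H]2O[C@@H](n3cnc4c(N)ncnc43)[C@H](O)[C@@H]2O)c1` differs from compound 1 by carboxymethyl in place of carboxy on a saturated chain carbon, three bonds along the chain from an amine nitrogen. In this assay compound 2 likewise gives only a limit, > 250000 nM. The step that the two limits leave unreadable from compound 1 to compound 2 therefore cannot be read. Compound 3 `Nc1ncnc2c1ncn2[C@@H]1O[C@H](CN(CCCC(=O)O)Cc2cccc(C(=O)O)c2)[C@@H](O)[C@H]1O` carries a different core, which differs from that of compound 1 by hydrogen in place of methyl on an oxygen next to a carbonyl group. In this assay compound 3 again gives only a limit, > 250000 nM. Within the data shown here, the step that the two limits leave unreadable from compound 1 to compound 3 is equally unreadable because every value so far sits at the limit of > 250000 nM in this assay, at which 3 of the 3 values shown sit.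

Compound 4 `Nc1ncnc2c1ncn2[C@@H]1O[C@H](CN(CCCCC(=O)O)Cc2cccc(C(=O)O)c2)[C@@H](O)[C@H]1O` has not yet been measured. It differs from compound 3 by carboxymethyl in place of carboxy on a saturated chain carbon, three bonds along the chain from an amine nitrogen, the same change that separates compound 1 from compound 2, at the same place. Since the earlier instance of this change left both compound 1 and compound 2 at the limit of > 250000 nM in this assay, at which 3 of the 3 values shown sit, the step that the limit leaves unreadable from compound 3 to compound 4 is expected to be small. Compound 4 is therefore expected to reach about 500000 nM in this assay, estimated between 150000 nM and 2000000 nM, most probably once more as a limit.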

Compound 4, half-maximal inhibitory concentration: > 250000 nM
Compound 4: no number, only a limit (the forecaster's own chance of this, stated with the estimate: 85%); the middle value is on the limit's open side.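

In this assay compound 4 gives > 250000 nM as well, which is only a limit. Among these compounds, no step to compound 4, from compound 3 or from compound 2, can be read, because all the values share one limit: the limit of > 250000 nM in this assay, at which 4 of the 4 values shown sit. The compounds shown leave open how strongly any of them inhibits in this assay and whether either change alters that.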